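The source may hold more compounds than are shown below. What is called first, only, known or untested is meant among the compounds shown, and "the series" means these compounds.

Working notes on the series. Compound 1 `C=C(Br)C(=O)Nc1ccc2c(c1)/C(=C\c1ccc(C)s1)C(=O)N2` carries a 5-methylthiophen-2-yl on a double-bonded chain carbon bound to a double-bonded ring carbon; in a functional assay on HL-60 cells (Homo sapiens) for antiproliferative activity, read by MTT assay, with a stated time of 72 h (on this read-out higher numbers stand for weaker inhibition and lower numbers for stronger inhibition), compound 1 gives 12 nM. Compound 2 `C=C(Br)C(=O)Nc1ccc2c(c1)/C(=C\c1sccc1C)C(=O)N2` differs by 3-methylthiophen-2-yl in place of 5-methylthiophen-2-yl on a double-bonded chain carbon bound to a double-bonded ring carbon; in this assay compound 2 gives 39 nM, and the step is a 3.3-fold higher number from compound 1 to compound 2 (0.51 log units; beyond the scatter). Compound 3 `C=C(Br)C(=O)Nc1ccc2c(c1)/C(=C/c1ccc(C)s1)C(=O)N2` is the other double-bond geometry of compound 1; in this assay compound 3 gives 24 nM, a step of a 2.0-fold higher number from compound 1 to compound 3 (0.30 log units; within the scatter), which fits (the fact that compounds 1 and 3 differ only in the configuration as drawn).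

Compound 4 `C=C(Br)C(=O)Nc1ccc2c(c1)/C(=C/c1sccc1C)C(=O)N2` has not been measured in this assay. It stands to compound 3 as compound 2 stands to compound 1: the change is 3-methylthiophen-2-yl in place of 5-methylthiophen-2-yl on a double-bonded chain carbon bound to a double-bonded ring carbon, the same change that was made from compound 1 to compound 2, on the same place word for word. The two cores differ by the two compounds have the same atoms and bonds and differ only in configuration as drawn: 1 of 1 stereo elements differ; a double bond is drawn E in compound 1 and Z in compound 3.

Going by the values given here, the step is expected to repeat at about the size seen from compound 1 to compound 2, since that is the only measured instance of this change; the step from compound 3 to compound 4 is estimated at a 3.1-fold higher number from compound 3 to compound 4 (0.49 log units; beyond the scatter), resting on compound 3 at 24 nM. Compound 4 is therefore expected to give about 75 nM in this assay, likely between 35 nM and 160 nM.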

Compound 4, half-maximal inhibitory concentration: 13 nM
The estimate for compound 4 lay 5.8-fold (0.76 log units) above the measured number; the whole stated range lies above it.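

The step of a 1.8-fold lower number from compound 3 to compound 4 (0.27 log units; within the scatter) does not repeat the one seen on the core of compound 1, so in this assay this change does not carry from one core to the other as a fixed increment: the same change on two cores in this assay, a 3.3-fold higher number (0.51 log units; beyond the scatter) from compound 1 to compound 2 and a 1.8-fold lower number (0.27 log units; within the scatter) from compound 3 to compound 4, 6.0-fold (0.78 log units) apart, beyond the scatter of two such steps. The double-bond geometry gives the same picture from the other side, with a 2.0-fold higher number from compound 1 to compound 3 (0.30 log units; within the scatter) for the 5-methylthiophen-2-yl pair and a 3.0-fold lower number from compound 2 to compound 4 (0.48 log units; beyond the scatter) for the 3-methylthiophen-2-yl pair. This rests on one exchange on one pair of cores, so it shows that the two cores can answer differently, but it gives no reason for the difference and no rule for any other group.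

Going by these compounds, it remains open whether the same dependence on double-bond geometry appears with a phenyl or a furan-2-yl in place of the methylthiophene, or with an ethyl in place of the methyl. The compounds shown also leave open whether it persists when a chlorine replaces the bromine on the shared core.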